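Benzyl Ether Swap on a Thiourea Core

This account rests on a few compounds, and the source may have more. Where it says the series, first, only, none or still open, it means among the compounds named here.

Compound 1 `Cc1ccc(NC(=S)NC(=O)c2ccc(OCc3cccc(Cl)c3)cc2)cc1-c1nc2ccccc2[nH]1`: 43300 nM
Compound 2 `Cc1ccc(NC(=S)NC(=O)c2ccc(OCc3cccc(C(F)(F)F)c3)cc2)cc1-c1nc2ccccc2[nH]1`: 6050 nM

Of the compounds shown here, two have been tested in a functional assay on MNK45 cells (Homo sapiens) for inhibition, read by MTT assay, with a stated time of 48 h (on this read-out higher numbers stand for weaker inhibition and lower numbers for stronger inhibition), and compound 2 gives the lower of the two numbers there, compound 1 the higher. Within the data shown here, the only measured step is a 7.2-fold lower number from compound 1 to compound 2 (0.85 log units; beyond the scatter), which involves exchanging one group for another at the same spot on the benzyl ring.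

Compound 3 `Cc1ccc(NC(=S)NC(=O)c2ccc(OCc3ccc(F)cc3)cc2)cc1-c1nc2ccccc2[nH]1` differs from compound 2 by 4-fluorophenyl in place of 3-(trifluoromethyl)phenyl on a saturated chain carbon bound to an oxygen on an aromatic ring. Among the measured compounds shown here, this change moves to a different part of the benzyl ring and introduces a group unlike either of the two already measured, so the single step on record does not directly describe it. The measured compounds show that this benzyl ring is a place where changes matter beyond the scatter, which is the main guide.

Compound 3 is expected to come out at 20000 nM, within 5000 nM to 60000 nM, with a 3.3-fold higher number from compound 2 to compound 3 (0.52 log units; beyond the scatter) as the estimated step from compound 2.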

Compound 3, half-maximal inhibitory concentration: 4220 nM
Beside the measured number, compound 3's estimate is 4.7-fold (0.68 log units) above it; the measured number lies below the stated range.
By their numbers in this assay, from the lowest: compounds 3 and 2 (each within the scatter of the next); then compound 1.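

In this assay putting 4-fluorophenyl in place of 3-(trifluoromethyl)phenyl gives a 1.4-fold lower number from compound 2 to compound 3 (0.16 log units; within the scatter) and so shows that two clearly different groups at this position can give values that cannot be told apart. Among these compounds, replacing 3-chlorophenyl with the same 4-fluorophenyl gives a 10-fold lower number from compound 1 to compound 3 (1.01 log units; beyond the scatter) and shows that trifluoromethyl is not the only group here that gives a number well under that of compound 1. Nothing available explains why these groups give these numbers.

From the compounds shown here alone, compound 2 and compound 3 differ in both the group and where it sits on the ring, so the contribution of each remains open. Also open, going by these compounds, is how the number would respond to an amine or a carboxylic acid on this benzyl ring, or to a longer chain in place of the benzyl carbon.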